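One Chloro Removed from the Shared Core

The source may hold more compounds than are shown below. What is called first, only, known or untested is meant among the compounds shown, and "the series" means these compounds.

Three compounds that share a core were tested in a functional assay on U-251 cells (Homo sapiens) for cytotoxicity, read by sulforhodamine B assay, with a stated time of 48 h; on this read-out higher numbers stand for weaker inhibition of growth and lower numbers for stronger inhibition of growth. Compound 1 `ClCc1ccccc1Cn1cnc2c(Cl)nc(Cl)nc21` gives 1020 nM, compound 2 `ClCc1ccc(Cn2cnc3nc(Cl)nc(Cl)c32)cc1` gives 3230 nM, and compound 3 `ClCc1cccc(Cn2cnc3nc(Cl)nc(Cl)c32)c1` gives 2690 nM. Compound 2 stands at the highest number of the three. Its nearest neighbour is compound 3, whose number lies within the usual scatter of repeated measurements, so no order between those two can be claimed. Compound 1 is furthest away, with a lower number, and that gap lies beyond the scatter.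

Compound 4 `ClCc1ccc(Cn2cnc3ncnc(Cl)c32)cc1` has not yet been measured in this assay. It differs from compound 2 in one place: hydrogen in place of chloro on an aromatic carbon. Among the compounds with values here, no pair of measured compounds shows this same change, so its size and direction cannot be read from the numbers above.

The expectation therefore rests only on how small the change is and on where compound 2 already sits. The step from compound 2 to compound 4 is estimated at a 1.5-fold higher number from compound 2 to compound 4 (0.19 log units; within the scatter), a modest move toward a higher number that may well fall within the scatter. On that basis compound 4 is expected to give about 5000 nM in this assay, with a plausible range from 1500 nM to 16000 nM.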

Compound 4, concentration for total growth inhibition: 2290 nM
Compound 4: the middle estimate sits 2.2-fold (0.34 log units) above what was measured, and the stated range covers the measured number.
By their numbers in this assay, from the lowest: compound 1; then compounds 4, 3 and 2 (each within the scatter of the next).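

In this assay, within the data shown here, putting hydrogen in place of chloro on the aromatic carbon between two ring nitrogen atoms gives a 1.4-fold lower number from compound 2 to compound 4 (0.15 log units; within the scatter), so this is the first direct look at this change and the two compounds cannot be told apart. At this position, in a compound that keeps its other chloro and its chloromethyl group, the chloro can therefore be lost with no change in growth inhibition that stands clear of ordinary repeat-to-repeat variation, though this rests on a single pair. Nothing measured here offers a reason for this result.

The compounds shown leave open whether the same exchange would be as quiet on compound 1 or compound 3, where the chloromethyl group sits elsewhere on the benzene ring and the gap to compound 2 is larger for compound 1. They also leave open whether a different group on this same carbon, such as an amine, a methoxy group or a longer chain, would shift the number by more than the scatter, in either direction.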